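Trimming the Ring Substituent on a Glutamate Receptor Series

A few compounds are considered here, and "the series" means these few. Any claim that something is new, unique, unknown or untested is made for them only; others in the source may bear on it.

Compound 2 `O=C1c2c(cc(OCc3ccc(-c4nn[nH]n4)cc3)c(Cl)c2Cl)CC1C1CCCC1` gives 122 nM in an assay on isolated protein for binding affinity to metabotropic glutamate receptor 2 (Homo sapiens) (a higher number here means that more compound is needed for the effect, a lower number that less compound is needed), the lowest of the two numbers at hand, while compound 1 `CC1(C2CCCC2)Cc2cc(OCCOc3ccc(-c4nn[nH]n4)cc3)c(Cl)c(Cl)c2C1=O` gives 276 nM in this assay. Compound 3 `CC(C)C1Cc2cc(OCc3ccc(-c4nn[nH]n4)cc3)c(Cl)c(Cl)c2C1=O` carries isopropyl in place of cyclopentyl on a saturated ring carbon, isopropyl in place of cyclopentyl on a saturated ring carbon. No change of a single place has been measured in this series, so the step is judged from the structures alone, and a modest rise in this assay is expected, probably just beyond the scatter. Compound 3 is estimated at 260 nM, with a range from 100 nM to 700 nM. This corresponds to an expected step of a 2.1-fold higher number from compound 2 to compound 3 (0.33 log units; beyond the scatter).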

Compound 3, half-maximal effective concentration: 195 nM
Estimate against measurement, compound 3: 1.3-fold (0.12 log units) above; the range from low to high includes it.
By their numbers in this assay, from the lowest: compounds 2, 3 and 1 (each within the scatter of the next, the first and the last beyond it).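

In this assay, among the compounds shown here, isopropyl in place of cyclopentyl on a saturated ring carbon gives a 1.6-fold higher number from compound 2 to compound 3 (0.20 log units; within the scatter) and provides the first single-place step. On this carbon, then, the five-membered ring can be replaced by an open group with fewer carbons without a difference that clears the scatter. No measurement at hand gives a reason for this result. Still open, as far as these compounds go, is how an amine, a carboxylic acid or a longer chain would fare on this carbon, and whether a methyl group added there would matter.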